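The source may report more compounds than this note shows. Statements on the series, on what has been measured and on what is new or still open speak of the compounds shown alone.

Compound 1 `Cc1cc(C)c(S(C)(=O)=O)cc1C(=O)N=C(N)N` gives 11 nM in a functional assay for inhibition of sodium/hydrogen exchanger (Oryctolagus cuniculus); a lower number here means a stronger inhibitor, a higher number a weaker inhibitor. Compound 2 `Cc1cc(Sc2ccccc2Cl)c(S(C)(=O)=O)cc1C(=O)N=C(N)N` gives 14 nM in this assay. Compound 3 `CS(=O)(=O)c1cc(C(=O)N=C(N)N)c(N2CCCCC2)cc1N1CCCCC1` gives 1000 nM in this assay.

Among these three numbers compound 2 stands second highest. Its nearest neighbour is compound 1, and the step of a 1.3-fold higher number from compound 1 to compound 2 (0.10 log units; within the scatter) lies within the scatter, so the two compounds cannot be told apart. Among the compounds with values here, compound 3, with its two piperidin-1-yl groups, sits far higher, beyond the scatter, but it differs from compound 2 in more than one place and gives no single step to lean on.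

Compound 4 `Cc1cc(-n2cccn2)c(S(C)(=O)=O)cc1C(=O)N=C(N)N` is the unmeasured compound; it differs from compound 2 by 1H-pyrazol-1-yl in place of (2-chlorophenyl)sulfanyl on an aromatic carbon. Within the data shown here, the only single step on record at this position is a 1.3-fold higher number from compound 1 to compound 2 (0.10 log units; within the scatter), which was flat: exchanging methyl for a much larger (2-chlorophenyl)sulfanyl group left the number unchanged. On that basis the change to 1H-pyrazol-1-yl is expected to give no step beyond the scatter, a 1.1-fold higher number from compound 2 to compound 4 (0.03 log units; within the scatter). Compound 4 is therefore estimated at 15 nM, with a range from 5 nM to 50 nM.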

Compound 4, half-maximal inhibitory concentration: 25 nM
Compound 4: the middle estimate sits 1.7-fold (0.22 log units) below what was measured, and the stated range covers the measured number.
By their numbers in this assay, from the lowest: compounds 1, 2 and 4 (each within the scatter of the next, the first and the last beyond it); then compound 3.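

In this assay, the position ortho to the methylsulfonyl group now carries a third kind of group, and exchanging (2-chlorophenyl)sulfanyl for the smaller 1H-pyrazol-1-yl stays within the scatter, a 1.8-fold higher number from compound 2 to compound 4 (0.25 log units; within the scatter). Set against the methyl group, however, the same 1H-pyrazol-1-yl gives the first step at this position that passes the scatter, a 2.3-fold higher number from compound 1 to compound 4 (0.36 log units; beyond the scatter), though only modestly, so the position is not wholly indifferent to what it carries. Nothing on record accounts for this small step.

From the compounds shown here alone, whether an amine such as dimethylamino or a carboxylic acid at this position would move the number further remains open. How a single piperidin-1-yl group would behave here also stays unresolved, as compound 3 differs from the other compounds in more than one place.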